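Swapping Butoxy for Dimethylamino: an Expected Loss

This account rests on a few compounds, and the source may have more. Where it says the series, first, only, none or still open, it means among the compounds named here.

Compound 1 `CCn1c(=O)c2nc(-c3ccc(S(=O)(=O)O)cc3)[nH]c2n(CC)c1=O`: 755 nM
Compound 2 `CCCCOc1ccc(-c2nc3c(=O)n(C)c(=O)n(C)c3[nH]2)cc1`: 4 nM

Both compounds were measured in an assay for binding affinity to adenosine receptor A1 (Bos taurus); on this read-out higher numbers stand for weaker inhibition and lower numbers for stronger inhibition. Compound 2 gives the lowest of the two numbers, and compound 1 sits at a far higher number, a gap well beyond the usual scatter. Compound 3 `CN(C)c1ccc(-c2nc3c(=O)n(C)c(=O)n(C)c3[nH]2)cc1` has not yet been measured in this assay. It differs from compound 2 in one place: dimethylamino in place of butoxy on an aromatic carbon. For the measured compounds named here, no measured pair shows this same change, so the size of the step is open. A moderate move toward a higher number, beyond the scatter, is expected, a 5.0-fold higher number from compound 2 to compound 3 (0.70 log units; beyond the scatter). Compound 3 is estimated to give 20 nM, within 4 nM to 100 nM.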

Compound 3, half-maximal inhibitory concentration: 1.8 nM
For compound 3 the middle estimate is 11-fold (1.05 log units) above the measured one, and the stated range ends above it.
By their numbers in this assay, from the lowest: compound 3; then compound 2; then compound 1.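

In this assay the butoxy chain on this aromatic carbon proves unnecessary for a low number. Dimethylamino, a group with fewer heavy atoms, brings a 2.2-fold lower number from compound 2 to compound 3 (0.35 log units; beyond the scatter) and so goes slightly further than butoxy, by a modest step. Nothing on record explains this step.

As far as these compounds go, whether methylamino, which keeps a hydrogen on the nitrogen, or a carboxylic acid on this carbon would hold the number this low stays open. This single step also leaves open whether the same swap would act alike on another core.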